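The compounds below may be only part of what the source reports. "The series", "measured", "known", "first", "only" and "open" are said of these compounds alone.

Measured in an ADME assay on L02 cells (Homo sapiens) for cytotoxicity, read by MTT assay, with a stated time of 48 h; on this read-out higher numbers stand for weaker inhibition and lower numbers for stronger inhibition:

- Compound 1 `Cc1cccc(Cn2cc(COc3ccc4c(=O)ccoc4c3)nn2)c1` gives > 300000 nM, a limit of the assay and not a number.
- Compound 2 `Cc1ccc(Cn2cc(COc3ccc4c(=O)ccoc4c3)nn2)cc1` gives > 300000 nM, likewise a limit.
- Compound 3 `N#Cc1ccc(Cn2cc(COc3ccc4c(=O)ccoc4c3)nn2)cc1` gives > 300000 nM, again a limit.

Compound 3 therefore stands at the limit of this assay, as do the two other measured compounds; no numerical order among them can be read. The steps a step that the two limits leave unreadable from compound 1 to compound 2, a step that the two limits leave unreadable from compound 1 to compound 3 and a step that the two limits leave unreadable from compound 2 to compound 3 cannot be sized because the limit of > 300000 nM in this assay, at which 3 of the 3 values shown sit, holds all three values.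

Compound 4 `O=c1ccoc2cc(OCc3cn(Cc4ccc([N+](=O)[O-])cc4)nn3)ccc12` is the next member: nitro in place of cyano on an aromatic carbon. Among the compounds with values here, none of the measured steps touches a nitro group, and the step that exchanges methyl for cyano on the same ring was itself unreadable, so nothing in the set points toward a readable change. The expectation is that compound 4 stays at the limit like compound 3, so the step that the limit leaves unreadable from compound 3 to compound 4 is estimated to be within the scatter. Compound 4 is estimated at 400000 nM, with a range from 150000 nM to 1500000 nM.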

Compound 4, half-maximal inhibitory concentration: > 300000 nM
Compound 4: a limit, no number; the forecaster's own chance of this, stated with the estimate: 85%; the middle value lies beyond the limit too.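

In this assay no step among compound 1, compound 2, compound 3 and compound 4 can be read, because all four values are limits and not numbers: the limit of > 300000 nM in this assay, at which 4 of the 4 values shown sit.

The compounds shown leave open whether any of these changes alters the read-out, and at what concentration any of them would inhibit these cells.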